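The source may report more compounds than this note shows. Statements on the series, on what has been measured and on what is new or still open speak of the compounds shown alone.

Series notes, measured in a functional assay on HCT-116 cells (Homo sapiens) for antiproliferative activity; a higher number here means that more compound is needed for the effect, a lower number that less compound is needed:

- compound 1 `Cc1c2c(n3c1CCN(C(=O)[C@H](C)N)CC[C@H](C)Nc1cc-3ccc1C(N)=O)CC(C)(C)CC2=O`: 314 nM
- compound 2 `Cc1c2c(n3c1CCCNC[C@H](C)Nc1cc-3ccc1C(N)=O)CC(C)(C)CC2=O`: 93 nM
- compound 3 `Cc1c2c(n3c1CC(=O)NCC[C@H](C)Nc1cc-3ccc1C(N)=O)CC(C)(C)CC2=O`: 815 nM

Compound 1 holds the middle place among the three numbers. Compound 3 reads higher and compound 2 reads lower, and both gaps lie beyond the scatter.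

The next compound to be tested is compound 4 `Cc1c2c(n3c1CCN(C(=O)CN)CC[C@H](C)Nc1cc-3ccc1C(N)=O)CC(C)(C)CC2=O`. Its difference from compound 1 is hydrogen in place of methyl on a saturated chain carbon bound to an amine nitrogen and a carbonyl carbon. In words, this is hydrogen in place of methyl on a saturated chain carbon bound to an amine nitrogen and a carbonyl carbon, so that 1-aminoethyl becomes aminomethyl.

Going by the values given here, no pair of measured compounds differs in one place only, so the data hold no direct precedent for this change. Any expectation therefore rests on compound 1 at 314 nM, and the uncertainty stays wide. The change is small, so no step beyond the scatter is expected in this assay, and no direction is favoured with any confidence. The estimated step is a 1.1-fold higher number from compound 1 to compound 4 (0.05 log units; within the scatter).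

For compound 4 the expected value is 350 nM, with an estimated range of 150 nM to 800 nM.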

Compound 4, half-maximal effective concentration: 1010 nM
For compound 4 the middle estimate is 2.9-fold (0.46 log units) below the measured one, and the stated range ends below it.
By their numbers in this assay, from the lowest: compound 2; then compound 1; then compounds 3 and 4 (each within the scatter of the next).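

In this assay, going by these compounds alone, the change from 1-aminoethyl to aminomethyl gives a 3.2-fold higher number from compound 1 to compound 4 (0.51 log units; beyond the scatter) and is the first step that can be read at a single place. It shows that the methyl on this saturated chain carbon, bound to an amine nitrogen and a carbonyl carbon, is not interchangeable with hydrogen here: the loss of one heavy atom, with no hydrogen-bond donors or acceptors and no net charge involved, moves the number beyond the scatter, and compound 1, which carries the methyl, needs less compound for the effect. No measurement shown here bears on the origin of this step.

A single pair leaves open whether the trend continues with a larger group on this carbon, such as ethyl or isopropyl, or whether it depends on the size of the group at all. The compounds shown also leave open how the opposite configuration of the methyl-bearing carbon, or a hydroxymethyl group in place of the methyl, would read in this assay on the same core.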